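Amine swap on the shared core: compound 2 to compound 3

A few compounds are considered here, and "the series" means these few. Any claim that something is new, unique, unknown or untested is made for them only; others in the source may bear on it.

Compound 1 `CCC(CC)Nc1nc(C)nc2c1nnn2-c1c(C)cc(C)cc1C` and compound 2 `CCCCN(CC)c1nc(C)nc2c1nnn2-c1ccc(C(C)C)cc1Br` carry the same core. In an in vitro assay on 293-EBNA cells for binding affinity to corticotropin-releasing factor receptor 1 (Homo sapiens) (on this read-out higher numbers stand for weaker inhibition and lower numbers for stronger inhibition), compound 1 gives 5.7 nM, and compound 2 gives 7.5 nM; the two numbers lie within the usual scatter of each other, so compound 2 stands alongside compound 1 with no separation that can be read. Compound 3 `COCCCNc1nc(C)nc2c1nnn2-c1ccc(C(C)C)cc1Br` has not yet been measured in this assay. The change from compound 2 is (3-methoxypropyl)amino in place of butyl(ethyl)amino on an aromatic carbon. With no measured step of this kind in the series, only a small shift is expected, if any, leaning toward a somewhat higher number: the step from compound 2 to compound 3 is estimated at a 1.6-fold higher number from compound 2 to compound 3 (0.20 log units; within the scatter). Compound 3 is expected to give about 12 nM, in a range from 4 nM to 40 nM.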

Compound 3, inhibition constant: 291 nM
The estimate for compound 3 lay 24-fold (1.38 log units) below the measured number; measured number above the stated range.
By their numbers in this assay, from the lowest: compounds 1 and 2 (each within the scatter of the next); then compound 3.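

On this aromatic carbon, next to the ring nitrogen, the amine is not freely interchangeable: in this assay, (3-methoxypropyl)amino in place of butyl(ethyl)amino gives a 39-fold higher number from compound 2 to compound 3 (1.59 log units; beyond the scatter), a large step with the rest of compound 2 unchanged. The entering group differs in more than one way, carrying an oxygen and a hydrogen-bond donor that butyl(ethyl)amino lacks, so the step cannot be divided between these features. Nothing available explains the step. Still open, going by these compounds, is whether butylamino would follow compound 3, or whether ethyl(3-methoxypropyl)amino would stay closer to compound 2.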